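The compounds below may be only part of what the source reports. "The series", "measured", "known", "first", "only" and "open" are said of these compounds alone.

Measured compounds in an assay on HL-60 cells for agonist activity at vitamin D3 receptor (Homo sapiens), read by microscopy, with a stated time of 96 h; on this read-out lower numbers stand for an effect already at smaller amounts and higher numbers for an effect only at larger amounts of compound:

compound 1 `CC[C@@H](C)[C@H](NC(=O)c1ccc(C(CC)(CC)c2ccc(OCC(=O)C(C)(C)C)c(C)c2)n1CC)C(=O)OC`: 590 nM
compound 2 `CCN(CC)CCCNC(=O)c1ccc(C(CC)(CC)c2ccc(OCC(=O)C(C)(C)C)c(C)c2)n1CC`: 22 nM
compound 3 `CCN(CC)CCCNC(=O)c1ccc(C(CC)(CC)c2ccc(OCC(O)C(C)(C)C)c(C)c2)n1CC`: 66 nM

Compound 3 stands second of the three numbers in this assay : compound 2 sits at a lower number, a 3.0-fold higher number from compound 2 to compound 3 (0.48 log units; beyond the scatter), and compound 1 at a higher one, with a 27-fold lower number from compound 1 to compound 2 (1.43 log units; beyond the scatter) separating the two ends of the set.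

Compound 4 `CCn1c(C(=O)N(CCC#N)CCC#N)ccc1C(CC)(CC)c1ccc(OCC(O)C(C)(C)C)c(C)c1` keeps the core and the 1-hydroxy-2,2-dimethylpropyl side of compound 3 and changes the amide side only: a group of 9 heavy atoms (6 carbon, 3 nitrogen; no ring) in place of a group of 9 heavy atoms (7 carbon, 2 nitrogen; no ring), on a carbonyl carbon. The group that leaves carries one hydrogen-bond donor and one acceptor; the group that enters carries no donor, two acceptors and two triple bonds outside aromatic rings.

Among the compounds with values here, the one measured step that bears on this position is the change on the amide-type nitrogen, a 27-fold lower number from compound 1 to compound 2 (1.43 log units; beyond the scatter), which shows that the group on that nitrogen can move the number far in this assay. Within the data shown here, no measured step tells in which direction a bis-nitrile group moves it. Given that the only well-tolerated amide substituent seen so far is the one that leaves, a step toward a higher number is expected, a 4.5-fold higher number from compound 3 to compound 4 (0.66 log units; beyond the scatter), with wide uncertainty. Compound 4 is therefore estimated at 300 nM, within 70 nM to 1500 nM.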

Compound 4, half-maximal effective concentration: 97 nM
For compound 4 the middle estimate is 3.1-fold (0.49 log units) above the measured one; measured number inside the range.
By their numbers in this assay, from the lowest: compound 2; then compounds 3 and 4 (each within the scatter of the next); then compound 1.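

Notes on the amide side, read in this assay: the step on the carbonyl carbon is a 1.5-fold higher number from compound 3 to compound 4 (0.17 log units; within the scatter), so compound 3 and compound 4 cannot be told apart on this read-out. The step of a 27-fold lower number from compound 1 to compound 2 (1.43 log units; beyond the scatter) had shown that the amide substituent can matter a great deal, and had left (3-(diethylamino)propyl)amino as the only substituent with a low number; this position now also accepts a group with no diethylamino end, no amide hydrogen and no hydrogen-bond donor, carrying nitrile groups instead, at a number that cannot be separated from that of compound 3. No measurement given here explains this tolerance.

From the compounds shown here alone, the reading holds only with the 1-hydroxy-2,2-dimethylpropyl side, so it remains open whether the same exchange would behave alike with the (tert-butyl)carbonyl side of compound 2. Also open, going by these compounds, is where a single 2-cyanoethyl chain, a carboxylic acid or a longer chain ending in a piperidine would fall on this carbonyl carbon, and whether any of these would separate from compound 3 beyond the usual scatter.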